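The source may hold more compounds than are shown below. What is called first, only, known or untested is meant among the compounds shown, and "the series" means these compounds.

In a functional assay on UACC-62 cells (Homo sapiens) (a higher number here means a weaker inhibitor of growth, a lower number a stronger inhibitor of growth), compound 1 `O=S(=O)(/C=C/c1ccccc1)Cc1ccc(Nc2ncnc3ccccc23)cc1` gives only a limit, > 100000 nM. For the measured compounds named here, compound 2 `O=S(=O)(/C=C/c1ccc(F)cc1)Cc1ccc(Nc2ncnc3ccccc23)cc1` gives 5000 nM, the only actual number so far. Going by the values given here, the one measured step, an at least 20-fold lower number from compound 1 to compound 2 (1.30 log units; beyond the scatter), is large and puts fluoro in place of hydrogen on an aromatic carbon. Compound 3 `N#Cc1ccc(/C=C/S(=O)(=O)Cc2ccc(Nc3ncnc4ccccc34)cc2)cc1` changes that same carbon, with cyano in place of fluoro (cyano in place of fluoro on an aromatic carbon). Among the compounds with values here, the large size of an at least 20-fold lower number from compound 1 to compound 2 (1.30 log units; beyond the scatter) suggests that this carbon matters, but no measured step compares fluoro with cyano, so no clear direction can be expected. The estimated 1.2-fold higher number from compound 2 to compound 3 (0.08 log units; within the scatter) therefore stays within the scatter, with much uncertainty. For compound 3 the estimate is 6000 nM, with an expected range from 1000 nM to 50000 nM.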

Compound 3, concentration for 50% growth inhibition: > 100000 nM
Compound 3: no number, only a limit; the forecaster's own chance of this, stated with the estimate: 20%; middle value at least 16-fold (1.22 log units) from the limit.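

The change from fluoro to cyano on this carbon gives an at least 20-fold higher number from compound 2 to compound 3 (1.30 log units; beyond the scatter), so a lower number here does not follow from just any group replacing hydrogen. Compound 3 gives only a limit, not a number: the limit of > 100000 nM in this assay, at which 2 of the 3 values shown sit. The step from compound 1 to compound 3 cannot be read, and of the three groups shown on this carbon, only fluoro gives an actual number. The compounds shown leave open how chloro, methoxy or an amine would read at this carbon, and so whether fluoro stands alone here.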